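The compounds below may be only part of what the source reports. "The series", "measured", "known", "first", "only" and "open" are said of these compounds alone.

Compound 1, `COc1cc(O)c(C(=O)/C=C/c2ccc(F)cc2)c(OC)c1`, gives 49% in a functional assay on Caco-2 cells (Homo sapiens), read by fluorescence and BrdU incorporation, with a stated time of 48 h, tested at 10 uM; on this read-out higher numbers stand for a weaker effect at the one concentration tested and lower numbers for a stronger effect.
Compound 2, `COc1cc(OC)c(C(=O)/C=C/c2ccc(Cl)cc2)c(OC)c1`, gives 39% in this assay.

Compound 1 carries the higher of the two numbers recorded so far, but the number of compound 2 lies only a little below it, and the gap between them falls inside the usual scatter of repeated measurements, so the two cannot be ranked against each other on this evidence. Among the measured compounds shown here, no step between two measured compounds that differ in a single place is available.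

The compound that remains to be measured is compound 3, `COc1cc(OC)c(C(=O)/C=C/c2ccc(F)cc2)c(OC)c1`. It departs from compound 1 by one change: methyl in place of hydrogen on an oxygen on an aromatic ring. Nothing in the measured pair shows what this change does on its own, so the size of the step can only be guessed. Compound 3 shares the methoxy groups of compound 2. With compound 1 at 49% and compound 2 at 39%, the expected step in this assay, a number 5 percentage points lower from compound 1 to compound 3 (within the scatter), is small and not beyond the scatter. Compound 3 is therefore estimated at 44%, within a range from 25% to 65%.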

Compound 3, a percentage reported as activity, at one concentration (the size of the read-out at that concentration, not a potency): 39%
Compound 3: middle estimate off by 5 percentage points, on the high side; the measured number falls inside the stated range.
By their numbers in this assay, from the lowest: compounds 2, 3 and 1 (each within the scatter of the next).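

Hydroxy to methoxy on the aromatic ring, the first single change read at this position, gives a number 10 percentage points lower from compound 1 to compound 3 (within the scatter) in this assay, so on this read-out the methyl on the oxygen cannot be told apart from the hydrogen it stands in place of. The second pair adds a different place on the molecule: with the methoxy groups held constant, fluoro in place of chloro on an aromatic carbon gives no change at the digits printed from compound 2 to compound 3 (within the scatter), and the two halogens cannot be told apart here either. No independent measurement bears on either result, so the numbers give no explanation for them.

The compounds shown leave open whether a longer chain on that oxygen, or an amine in place of the hydroxy of compound 1, would give a number beyond the scatter of these three. They also leave open what a nitrile or a trifluoromethyl in place of the fluoro of compound 3 would give on the same read-out.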